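The source may hold more compounds than are shown below. What is called first, only, known or untested is meant among the compounds shown, and "the series" means these compounds.

In an ADME assay on L929 cells (Mus musculus) for cytotoxicity, read by resazurin assay, with a stated time of 48 h (on this read-out higher numbers stand for lower toxicity in this test and lower numbers for higher toxicity in this test), compound 3 (`CC(=O)OCCn1c2ccc([N+](=O)[O-])cc2c(=O)n1Cc1ccccc1`) gives > 256000 nM as a limit and not a number. Compound 1 (`CNC(=O)CCCn1c2ccc([N+](=O)[O-])cc2c(=O)n1Cc1ccccc1`) gives > 256000 nM as a limit too. Compound 2 (`COCCn1c2ccc([N+](=O)[O-])cc2c(=O)n1Cc1ccccc1`) likewise gives > 256000 nM as a limit. The series therefore stands at the limit of > 256000 nM in this assay, at which 3 of the 3 values shown sit, and offers no number for compound 3 to be ranked against.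

The change to compound 4 (`O=C(c1ccccc1)n1c2ccc([N+](=O)[O-])cc2c(=O)n1Cc1ccccc1`) is benzoyl in place of 2-acetoxyethyl on an aromatic nitrogen and amounts to benzoyl in place of 2-acetoxyethyl on an aromatic nitrogen, next to the ring atom that bears a benzyl group. Three measured steps come closest. They are a step that the two limits leave unreadable from compound 1 to compound 2 and then a step that the two limits leave unreadable from compound 1 to compound 3 and finally a step that the two limits leave unreadable from compound 2 to compound 3 with no size to carry over. All three alter the chain on that nitrogen, and none replaces it with benzoyl, so the data give no direct guide to this change.

Because the limit of > 256000 nM in this assay, at which 3 of the 3 values shown sit, holds for every compound measured, a reading close to that limit is expected, with only a modest move toward higher toxicity held possible. The expected step in this assay is an at least 1.4-fold lower number from compound 3 to compound 4 (0.15 log units; that floor lies within the scatter) and remains a tentative estimate. Compound 4 is estimated at 180000 nM with an expected range from 60000 nM to 256000 nM in this read-out.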

Compound 4, concentration lethal to 50% of the cells: 146000 nM
Beside the measured number, compound 4's estimate is 1.2-fold (0.09 log units) above it; measured number inside the range.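

In this assay, among the compounds shown here, compound 4 gives the only reading that is a number and not a limit, so benzoyl on this aromatic nitrogen, with its six-membered aromatic ring, brings the read-out within measurable range where the three open chains do not. Set against those chains, the change reads as an at least 1.7-fold lower number from compound 3 to compound 4 (0.24 log units; that floor lies within the scatter), as an at least 1.7-fold lower number from compound 2 to compound 4 (0.24 log units; that floor lies within the scatter) and as an at least 1.7-fold lower number from compound 1 to compound 4 (0.24 log units; that floor lies within the scatter); each of these is only a floor, and each floor lies within the scatter, so a true drop in the number is suggested and not established. The steps among the three chain compounds cannot be read, and the chains therefore remain unranked at one shared point: the limit of > 256000 nM in this assay, at which 3 of the 4 values shown sit.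

Still open, on these data alone, is whether the shift belongs to the carbonyl on the nitrogen or to the aromatic ring, which acetyl and a plain phenethyl group on the same nitrogen would separate. Also open, as far as these compounds go, is how far the number can move at this position, for instance with a substituted benzoyl or with a chain ending in an amine or a carboxylic acid.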